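Swapping Methylsulfonyl for Benzoyl: Expected Cytotoxicity of Compound 3

This account rests on a few compounds, and the source may have more. Where it says the series, first, only, none or still open, it means among the compounds named here.

Measured so far:
compound 1, `O=C(Nc1ccc(Cl)cc1)C1CCCN(C(=O)c2cccc(-c3nccs3)c2)C1`: 32%
compound 2, `CS(=O)(=O)c1cccc(C(=O)N2CCCC(C(=O)Nc3ccc(Cl)cc3)C2)c1`: 2%

In an ADME assay on PC-3 cells (Homo sapiens) for cytotoxicity, read by WST assay, tested at 100 uM (a lower number here means less inhibition, a higher number more inhibition at the concentration tested (going by the name of the read-out)), compound 2 gives 2%, the lowest of the two numbers; its nearest neighbour is compound 1, reached by the step of a number 30 percentage points lower from compound 1 to compound 2 (beyond the scatter). Compound 3, `O=C(c1ccccc1)c1cccc(C(=O)N2CCCC(C(=O)Nc3ccc(Cl)cc3)C2)c1`, differs from compound 2 as follows: benzoyl in place of methylsulfonyl on an aromatic carbon. Within the data shown here, the only measured step, a number 30 percentage points lower from compound 1 to compound 2 (beyond the scatter), concerns another exchange on an aromatic carbon and does not involve benzoyl, so it gives no direct guide. A modest rise is expected, a number 18 percentage points higher from compound 2 to compound 3 (beyond the scatter), because compound 1 with its aromatic group gave 32%. Compound 3 is therefore estimated at 20%, within 0% to 45%.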

Compound 3, a percentage reported as inhibition, at one concentration (the size of the read-out at that concentration, not a potency): 0%
Beside the measured number, compound 3's estimate is 20 percentage points above it; low and high end bracket the measured number.
By their numbers in this assay, from the lowest: compounds 3 and 2 (each within the scatter of the next); then compound 1.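

In this assay benzoyl in place of methylsulfonyl on an aromatic carbon gives a number 2 percentage points lower from compound 2 to compound 3 (within the scatter) and so does not separate the two groups, even though benzoyl brings a six-membered aromatic ring of carbon only. Benzoyl in place of 1,3-thiazol-2-yl at this place gives a number 32 percentage points lower from compound 1 to compound 3 (beyond the scatter) and shows that an aromatic ring in the group is not enough to reach the number of compound 1. Nothing available explains this result. The compounds shown leave open whether the number of compound 1 is specific to 1,3-thiazol-2-yl or would also appear with a directly attached phenyl or pyridyl. They also leave open what an amine or a carboxylic acid would give on this aromatic carbon.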